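Ethoxy for Trifluoromethyl on the Aryl Amine of Compound 3

The compounds below may be only part of what the source reports. "The series", "measured", "known", "first", "only" and "open" are said of these compounds alone.

Compound 1, `CCCCCCNc1nc(SCc2ccc(C(F)(F)F)cc2)nc2ccccc12`: in a functional assay on PC-3 cells (Homo sapiens) for cytotoxicity, read by MTT assay, with a stated time of 72 h (on this read-out higher numbers stand for weaker inhibition and lower numbers for stronger inhibition), compound 1 gives 19000 nM.
Compound 2, `CCCCCCCCNc1nc(SCc2ccc(C(F)(F)F)cc2)nc2ccccc12`: in this assay compound 2 gives 10500 nM.
Compound 3, `FC(F)(F)c1ccc(CSc2nc(Nc3ccccc3C(F)(F)F)c3ccccc3n2)cc1`: in this assay compound 3 gives 34800 nM.

Compound 3 carries the highest of the three numbers. Its nearest neighbour is compound 1, with a 1.8-fold higher number from compound 1 to compound 3 (0.26 log units; within the scatter); the furthest is compound 2, with a 3.3-fold higher number from compound 2 to compound 3 (0.52 log units; beyond the scatter). Compound 4, `CCOc1ccccc1Nc1nc(SCc2ccc(C(F)(F)F)cc2)nc2ccccc12`, differs from compound 3 by ethoxy in place of trifluoromethyl on an aromatic carbon. Among the measured compounds shown here, no measured step touches this group: a 1.8-fold lower number from compound 1 to compound 2 (0.26 log units; within the scatter) changes the length of the chain on the nitrogen, and the two steps to compound 3 exchange that chain for the aryl group. For the measured compounds named here, for the exchange on the aryl ring itself there is no precedent among the three compounds. With nothing to point either way, compound 4 is expected to sit close to compound 3, with a 1.2-fold lower number from compound 3 to compound 4 (0.06 log units; within the scatter) not beyond the scatter. Compound 4 is therefore estimated in this assay at 30000 nM, within 10000 nM to 90000 nM.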

Compound 4, half-maximal inhibitory concentration: 26200 nM
For compound 4 the middle estimate is 1.1-fold (0.06 log units) above the measured one, within the range that was stated.
By their numbers in this assay, from the lowest: compounds 2, 1, 4 and 3 (each within the scatter of the next, the first and the last beyond it).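

In this assay the exchange on the aryl ring itself can now be read, and with a 1.3-fold lower number from compound 3 to compound 4 (0.12 log units; within the scatter) ethoxy and trifluoromethyl cannot be told apart at this place, although ethoxy brings a hydrogen-bond acceptor that trifluoromethyl lacks. The 2-ethoxyphenyl group likewise cannot be separated from hexyl on the nitrogen, with a 1.4-fold higher number from compound 1 to compound 4 (0.14 log units; within the scatter) as the step, while against octyl it stands apart, with a 2.5-fold higher number from compound 2 to compound 4 (0.40 log units; beyond the scatter) as the step. Nothing available explains these numbers.

Whether this aryl position tolerates every group remains open, since only two groups are shown there, and an amine, a carboxylic acid or a methoxy group could give a different number. Also open, on these data alone, is how a chain longer than octyl on the nitrogen would compare.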